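The compounds below may be only part of what the source reports. "The series", "measured", "known", "first", "only" and "open" are said of these compounds alone.

Three members of one shared core have so far been tested in an ADME assay on Vero cells (Chlorocebus sabaeus) for cytotoxicity, with a stated time of 7 days; a higher number here means that more compound is tolerated, a lower number that less compound is tolerated. Compound 1 `COc1ccc2[nH]c(C(=O)N3CC(=O)N(Cc4ccccc4)[C@@H](COc4ccccc4)C3)cc2c1` reaches only the floor of what the assay reports: in this assay compound 1 gives > 10000 nM, which is a limit and not a number. Compound 2 `COc1cccc(CN2C(=O)CN(C(=O)c3cc4cc(OC)ccc4[nH]3)C[C@@H]2CC2CCCCC2)c1` likewise stops at a limit, giving > 10000 nM in this assay. Compound 3 `COc1ccc2[nH]c(C(=O)N3CC(=O)N(Cc4ccccc4)[C@@H](CN4CCN(c5ccc(F)cc5)CC4)C3)cc2c1`, whose side chain also carries a nitrogen in a non-aromatic ring, gives > 30000 nM in this assay, again a limit. For the measured compounds named here, compound 1 therefore stands where most of the set stands, at the limit of > 10000 nM in this assay, at which 2 of the 3 values shown sit, while the limit of > 30000 nM in this assay, at which 1 of the 3 values shown sits, marks the single member carried further. No two of these compounds differ in only one place, so no measured step is available.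

Compound 4 `COc1ccc2[nH]c(C(=O)N3CC(=O)N(Cc4ccccc4)[C@@H](CN4CC5CCCCC5C4)C3)cc2c1` has not yet been tested. It differs from compound 1 by a group of 9 heavy atoms (8 carbon, 1 nitrogen; one five-membered non-aromatic ring with 1 hetero atom, one six-membered non-aromatic ring of carbon only) in place of a group of 7 heavy atoms (6 carbon, 1 oxygen; one six-membered aromatic ring of carbon only), on a saturated chain carbon bound to a saturated ring carbon. Since every value seen so far is a limit, the step from compound 1 to compound 4 is expected to be none beyond the scatter, which corresponds to an expected step that the limit leaves unreadable from compound 1 to compound 4. In this assay compound 4 is expected to give about 20000 nM, within a range from 8000 nM to 60000 nM, and most likely to be reported once more as a limit rather than a number.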

Compound 4, half-maximal cytotoxic concentration: 8200 nM
For compound 4 the middle estimate is 2.4-fold (0.39 log units) above the measured one, within the range that was stated.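

For the compounds shown here, compound 4 is the first member of the set to give a number rather than a limit, which shows that a change at this position, on a saturated chain carbon bound to a saturated ring carbon, can bring the read-out in this assay within what the assay reports as a number. Replacing phenoxy with the group carrying a five-membered non-aromatic ring with one hetero atom and a six-membered non-aromatic ring of carbon only gives an at least 1.2-fold lower number from compound 1 to compound 4 (0.08 log units; that floor lies within the scatter), and this is only a floor, so it does not establish a real loss of tolerance on its own. The number therefore stands alone, and the lower limit still describes more of the set than any other single result: the limit of > 10000 nM in this assay, at which 2 of the 4 values shown sit.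

On these data alone, the true size of the step remains open, since compound 1 is known only through a limit, and a single entering group cannot show whether the ring nitrogen or the carbon rings matter more. A morpholine ring or an open-chain diethylamino group on the same saturated chain carbon would begin to separate those two parts of the change.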